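The compounds below may be only part of what the source reports. "The series", "measured", "known", "first", "only" and "open" are said of these compounds alone.

Compound 1 `Cc1c(Cl)cccc1Oc1cccn2c(C34CCC(CC3)C4)nnc12` gives 57% in an ADME assay on microsomes from liver (Mus musculus) for metabolic stability, with a stated time of 10 min (on this read-out lower numbers stand for a less stable compound and higher numbers for a more stable compound), the lowest of the two numbers shown, while compound 2 `Cc1c(Cl)cccc1Oc1cccn2c(C3CCC(C)(O)CC3)nnc12` gives 97% in this assay. Among the compounds with values here, the single measured step, a number 40 percentage points higher from compound 1 to compound 2 (beyond the scatter), swaps the two five-membered rings for one six-membered ring carrying an oxygen. Compound 3 `Cc1c(Cl)cccc1Oc1cccn2c(C34CCC(F)(CC3)CC4)nnc12` differs from compound 1 by a group of 9 heavy atoms (8 carbon, 1 fluorine; 2 six-membered non-aromatic rings of carbon only) in place of a group of 7 heavy atoms (7 carbon; 2 five-membered non-aromatic rings of carbon only), on an aromatic carbon. Here a carbon cage stays and a fluorine enters, so the measured step bears on it only loosely, and a rise expected to be smaller than that step, a number 13 percentage points higher from compound 1 to compound 3 (beyond the scatter), seems plausible. Compound 3 is accordingly estimated at 70%, in a range from 50% to 90%.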

Compound 3, percent of the compound remaining in the liver assay: 62%
The estimate for compound 3 lay 8 percentage points above the measured number, and the stated range covers the measured number.
By their numbers in the liver assay, from the lowest: compounds 1 and 3 (each within the scatter of the next); then compound 2.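

In the liver assay, compound 1 gives 57% and compound 3 gives 62%. The fluorine-bearing cage with two six-membered rings gives a number 5 percentage points higher from compound 1 to compound 3 (within the scatter), so changing the cage and adding fluorine at this position does not separate these two compounds. In the liver assay, the oxygen-bearing single ring remains distinct, with a number 35 percentage points lower from compound 2 to compound 3 (beyond the scatter). In a physicochemical assay for solubility, at pH 7.4 (on this read-out higher numbers stand for higher solubility and lower numbers for lower solubility), compound 1 gives 1 ug/mL and compound 3 gives 1 ug/mL, and the cage change gives no change at the digits printed from compound 1 to compound 3 (within the scatter). Nothing measured here explains these results. On these data alone, whether the higher stability of compound 2 goes with its oxygen or its single ring stays open. A cage carrying a hydroxyl group or an amine instead of fluorine would help separate the two.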